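Two weak inhibitors and a methylsulfanyl swap

The source may hold more compounds than are shown below. What is called first, only, known or untested is meant among the compounds shown, and "the series" means these compounds.

Compound 1 `OC[C@H]1OC(n2c(Cl)nc3c(Cl)cc(Cl)cc32)[C@H](O)[C@@H]1O`: 230000 nM
Compound 2 `Nc1nc2c(Cl)cc(Cl)cc2n1C1O[C@H](CO)[C@@H](O)[C@H]1O`: > 300000 nM

In a functional assay on KB cells (Homo sapiens) for inhibition (on this read-out lower numbers stand for stronger inhibition and higher numbers for weaker inhibition), compound 2 gives no number, only a limit, > 300000 nM. That is the limit of > 300000 nM in this assay, at which 1 of the 2 values shown sits. Compound 3 `CSc1nc2c(Cl)cc(Cl)cc2n1C1O[C@H](CO)[C@@H](O)[C@H]1O` has methylsulfanyl in place of amino on an aromatic carbon. Among the measured compounds shown here, the one measured step at this place is an at least 1.3-fold higher number from compound 1 to compound 2 (0.11 log units; that floor lies within the scatter), so the data bound it from one side only. For the measured compounds named here, with compound 1 at 230000 nM as the sole number, no step beyond the scatter is expected in this assay. The expected change is an at least 1.5-fold lower number from compound 2 to compound 3 (0.17 log units; that floor lies within the scatter). Compound 3 is estimated at 200000 nM, with an expected range from 70000 nM to 400000 nM.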

Compound 3, half-maximal inhibitory concentration: 270000 nM
Beside the measured number, compound 3's estimate is 1.4-fold (0.13 log units) below it; the measured number falls inside the stated range.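

In this assay, the place between two ring nitrogen atoms now carries a third group, methylsulfanyl, and the change from amino is an at least 1.1-fold lower number from compound 2 to compound 3 (0.04 log units; that floor lies within the scatter). Against chloro, the change is a 1.2-fold higher number from compound 1 to compound 3 (0.07 log units; within the scatter), so methylsulfanyl and chloro cannot be told apart at this place. The comparison with amino stays one-sided, since compound 2 has only a limit: the limit of > 300000 nM in this assay, at which 1 of the 3 values shown sits.

On these data alone, it remains open whether any group at this place can move the number beyond the scatter. A longer chain such as benzylsulfanyl, or a carboxylic acid, would test this.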